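The source may hold more compounds than are shown below. What is called first, only, known or untested is meant among the compounds shown, and "the series" means these compounds.

Within the data shown here, compound 2 `Cc1cc(=O)[nH]c2cc(N3C(=O)CSC3c3ccccc3[N+](=O)[O-])ccc12` stands highest of the two numbers measured so far in a functional assay on the whole organism (strain albino) for inhibition, with Rattus norvegicus as the target, read by paw edema, with stated times of 1 h and 3 h, at a dose of 100 mg/kg by the oral route (on this read-out lower numbers stand for less inhibition and higher numbers for more inhibition at the one dose given (going by the name of the read-out)), where compound 2 gives 24.1%; its nearest neighbour, compound 1 `COc1cc(C2SCC(=O)N2c2ccc3c(C)cc(=O)[nH]c3c2)ccc1O`, gives in this assay a value of 12.4%. Compound 3 `Cc1cc(=O)[nH]c2cc(N3C(=O)CSC3c3ccc(N(C)C)cc3)ccc12` has not yet been measured in this assay. It differs from compound 2 in one place: 4-(dimethylamino)phenyl in place of 2-nitrophenyl on a saturated ring carbon. Among the measured compounds shown here, the only measured step, from compound 1 to compound 2, also exchanged one aryl group for another at that same saturated ring carbon, and it moved the read-out by a number 11.7 percentage points higher from compound 1 to compound 2 (beyond the scatter). That single step shows that an aryl swap at this position can shift the number by a modest amount, but it does not show which way a second swap would go. He therefore expects for compound 3 in this assay a step of a number 6.1 percentage points lower from compound 2 to compound 3 (within the scatter), of the same modest order. His estimate for compound 3 in this assay is 18%, within the range 6% to 32%.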

Compound 3, a percentage reported as inhibition, in the whole organism at one dose (the size of the read-out at that dose, not a potency): 13.3%
Compound 3: the middle estimate sits 4.7 percentage points above what was measured; the measured number falls inside the stated range.
By their numbers in this assay, from the lowest: compounds 1 and 3 (each within the scatter of the next); then compound 2.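

In this assay, the step of a number 10.8 percentage points lower from compound 2 to compound 3 (beyond the scatter) shows that the higher reading of compound 2 does not extend to every aryl exchange at this saturated ring carbon, since 4-(dimethylamino)phenyl does not keep it. The step of a number 0.9 percentage points higher from compound 1 to compound 3 (within the scatter) adds that 4-(dimethylamino)phenyl and 4-hydroxy-3-methoxyphenyl cannot be told apart at this position, so among the three aryl groups shown, only 2-nitrophenyl stands apart from the other two. Nothing available gives a reason for this difference.

The compounds shown leave open whether an unsubstituted phenyl, or a phenyl bearing a carboxylic acid or a primary amine, would read with compound 2 or with compounds 1 and 3. They also leave open whether this order would hold at other doses.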